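The source may report more compounds than this note shows. Statements on the series, on what has been measured and on what is new or still open speak of the compounds shown alone.

Measured compounds in a functional assay on Raji cells (Homo sapiens) for cytotoxicity, read by CCK-8 assay, with a stated time of 24 h; on this read-out higher numbers stand for weaker inhibition and lower numbers for stronger inhibition:
compound 1 `C=CC(=O)N1C(=O)CC(c2ccc(C(=O)OC)cc2)Sc2ccccc21` — 89600 nM
compound 2 `C=CC(=O)N1C(=O)CC(c2ccc(C(F)(F)F)cc2)Sc2ccccc21` — 47600 nM
compound 3 `C=CC(=O)N1C(=O)CC(c2ccccc2Cl)Sc2ccccc21` — 50400 nM

Compound 3 gives the second highest of the three numbers in this assay; its nearest neighbour is compound 2, and its furthest is compound 1, and both of those gaps lie within the scatter. Within the data shown here, the same holds for the one step between measured compounds, a 1.9-fold lower number from compound 1 to compound 2 (0.27 log units; within the scatter), which exchanges one group on the aromatic ring for another.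

Compound 4 `C=CC(=O)N1C(=O)CCSc2ccccc21` has not yet been measured. It differs from compound 3 as follows: hydrogen in place of 2-chlorophenyl on a saturated ring carbon. Among the measured compounds shown here, no measured step resembles this change; the only step available, from compound 1 to compound 2, keeps the aromatic ring in place and alters only the group on it, and it stayed within the scatter. Nothing here therefore shows how this assay responds when the whole 2-chlorophenyl is removed. Since all three aromatic variants gave numbers of similar size, it is estimated that the shared core without that ring gives a higher number, that is, weaker inhibition, and that it may reach the upper limit of this assay.

Compound 4 is expected to give about 150000 nM, within a range of 60000 nM to 400000 nM, which would mean an estimated 3.0-fold higher number from compound 3 to compound 4 (0.47 log units; beyond the scatter).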

Compound 4, half-maximal inhibitory concentration: 581000 nM
For compound 4 the middle estimate is 3.9-fold (0.59 log units) below the measured one, and the stated range ends below it.
By their numbers in this assay, from the lowest: compounds 2, 3 and 1 (each within the scatter of the next); then compound 4.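

In this assay, replacing the 2-chlorophenyl on the saturated ring carbon next to the ring sulfur with hydrogen gives a 12-fold higher number from compound 3 to compound 4 (1.06 log units; beyond the scatter) and so weakens inhibition by a large step beyond the scatter. Among these compounds, the earlier compounds all kept an aromatic ring at this carbon and stayed within the scatter of one another, so they showed only that the changes among them left the number essentially unmoved. Compound 4 shows that this position is not indifferent: having the 2-chlorophenyl there rather than hydrogen makes a clear difference to the read-out, although no measurement shown gives a reason for a step of this size.

The compounds shown leave open whether the aromatic ring itself is what counts at this carbon, since a cyclohexyl ring or a short chain such as methyl or ethyl in the same place could behave like the 2-chlorophenyl or like hydrogen. They also leave open whether an amine or a carboxylic acid on the aromatic ring would stay within the narrow spread seen so far.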